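The source may report more compounds than this note shows. Statements on the series, on what has been measured and on what is new or still open speak of the compounds shown alone.

Compound 1 `COc1ccc(-c2ncnc3c2ncn3C[C@@H]2C[C@H](CO)c3ccccc32)cc1`: 17600 nM
Compound 2 `CC(=O)OCCOCn1cnc2c(=S)[nH]c(N)nc21`: 3200 nM
Compound 3 `O=C(CI)NCc1cn([C@H]2C[C@H](O)[C@@H](CO)O2)c(=O)[nH]c1=O`: 107000 nM

In an ADME assay on L1210/0 cells (Mus musculus) for cytotoxicity, with a stated time of 48 h (a lower number here means a stronger inhibitor, a higher number a weaker inhibitor), compound 1 gives 17600 nM and stands second highest of the three numbers. Compound 2 lies lower and compound 3 lies higher, and both gaps from compound 1 are beyond the usual scatter.

Compound 4 `COc1ncnc2c1ncn2C[C@@H]1C[C@H](CO)c2ccccc21` keeps the core of compound 1 but carries methoxy in place of 4-methoxyphenyl on an aromatic carbon. Among the measured compounds shown here, no measured pair here differs in one place, so the three values offer no direct guide to the effect of this change. In this assay, a moderate step towards a higher number, meaning a weaker inhibitor, is expected, although a result within the scatter of compound 1 would not be surprising. The estimated step is a 2.3-fold higher number from compound 1 to compound 4 (0.36 log units; beyond the scatter). For compound 4 the expected value is 40000 nM, with an estimated range from 12000 nM to 130000 nM.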

Compound 4, half-maximal inhibitory concentration: > 200000 nM
Compound 4: no number, only a limit (the forecaster's own chance of this, stated with the estimate: 20%); middle value at least 5.0-fold (0.69 log units) away from the limit.
By their numbers in this assay, from the lowest: compound 2; then compound 1; then compound 3. At a limit, above all of these: compound 4.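

In this assay, among the compounds shown here, the aromatic carbon that carries this group proves to be a sensitive place on the shared core: methoxy in place of 4-methoxyphenyl gives an at least 11-fold higher number from compound 1 to compound 4 (1.05 log units; beyond the scatter), the only comparison here between compounds that differ in one place. The change removes the six-membered aromatic ring of carbon only, while the count of hydrogen-bond donors and acceptors in the group stays the same, so the large step goes with the loss of that ring and not with a change in those counts. Compound 4 stands at a limit of the assay, not at a number: the limit of > 200000 nM in this assay, at which 1 of the 4 values shown sits.

The compounds shown leave open whether an unsubstituted phenyl, an amine or a longer alkoxy chain on this carbon would stay nearer to compound 1 or also reach the limit. With a single pair, they also cannot tell which part of the 4-methoxyphenyl group carries the difference.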